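Trimming One Methyl from the Ether Side Chain

This account rests on a few compounds, and the source may have more. Where it says the series, first, only, none or still open, it means among the compounds named here.

Of the compounds shown here, three sharing one core have been tested in a functional assay on PC-3 cells (Homo sapiens) for antiproliferative activity, read by sulforhodamine B assay; a higher number here means a weaker inhibitor of growth, a lower number a stronger inhibitor of growth. Compound 1 `O=C(/C=C/c1ccc(O)cc1)c1c(O)cccc1OCC1CCCCC1` reaches only the assay limit, > 30000 nM. Compound 2 `O=C(/C=C/c1ccc(O)cc1)c1c(O)cccc1OCc1ccccc1` likewise stops at the limit, > 30000 nM. Within the data shown here, compound 3 `CC(C)(C)CCOc1cccc(O)c1C(=O)/C=C/c1ccc(O)cc1` is the single compound with an actual number, giving 3220 nM in this assay. The steps of an at least 9.3-fold lower number from compound 1 to compound 3 (0.96 log units; beyond the scatter) and an at least 9.3-fold lower number from compound 2 to compound 3 (0.96 log units; beyond the scatter) both mark a move toward stronger growth inhibition, although the limit of > 30000 nM in this assay, at which 2 of the 3 values shown sit, leaves their full size unknown. Compound 4 `CC(C)CCOc1cccc(O)c1C(=O)/C=C/c1ccc(O)cc1` differs from compound 3 by hydrogen in place of methyl on a saturated chain carbon bound to three saturated chain carbons. Among the measured compounds shown here, no measured step touches this part of the chain, so nothing beyond the scatter is expected. The step of a 1.2-fold higher number from compound 3 to compound 4 (0.09 log units; within the scatter) is estimated to be small. Compound 4 is therefore expected to give about 4000 nM, between 1500 nM and 12000 nM.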

Compound 4, concentration for 50% growth inhibition: 11500 nM
Estimate against measurement, compound 4: 2.9-fold (0.46 log units) below; low and high end bracket the measured number.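

Even at a saturated chain carbon bound to three saturated chain carbons, hydrogen in place of methyl is not a silent change: the result is a 3.6-fold higher number from compound 3 to compound 4 (0.55 log units; beyond the scatter). The chain without that methyl still keeps an edge over the phenyl and cyclohexyl groups, with an at least 2.6-fold lower number from compound 2 to compound 4 (0.41 log units; beyond the scatter) and an at least 2.6-fold lower number from compound 1 to compound 4 (0.41 log units; beyond the scatter). The full size of these two steps cannot be read: the limit of > 30000 nM in this assay, at which 2 of the 4 values shown sit.

Going by these compounds, whether an ethyl or a trifluoromethyl at this carbon would give a lower or a higher number stays open. So does the effect of a longer chain.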